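Removing the Ester Group: Estimating the Free Triol

This account rests on a few compounds, and the source may have more. Where it says the series, first, only, none or still open, it means among the compounds named here.

Of the compounds shown here, two sharing one core have been tested in a functional assay on the whole organism (strain Sprague-Dawley) for inhibition, with Rattus norvegicus as the target, with a stated time of 0.5 h, at a dose of 5 mg/kg by the oral route; a higher number here means more inhibition at the dose given (going by the name of the read-out), a lower number less inhibition. Compound 1 `CCCSc1nc(N[C@@H]2C[C@H]2c2ccc(F)c(F)c2)c2nnn([C@@H]3C[C@H](OC(=O)CCC)[C@@H](O)[C@H]3O)c2n1` carries a propyl ester on one ring hydroxyl and gives 28.5%. Compound 2 `CCCSc1nc(N[C@@H]2C[C@H]2c2ccc(F)c(F)c2)c2nnn([C@@H]3C[C@H](OC(=O)OCC(C)C)[C@@H](O)[C@H]3O)c2n1` carries an isobutoxy carbonate in its place and gives 13.2%, the lower of the two values; the step of a number 15.3 percentage points lower from compound 1 to compound 2 (beyond the scatter) shows that putting isobutoxy in place of propyl on the carbonyl carbon cost a modest amount of inhibition. Compound 3 `CCCSc1nc(N[C@@H]2C[C@H]2c2ccc(F)c(F)c2)c2nnn([C@@H]3C[C@H](O)[C@@H](O)[C@H]3O)c2n1` strips the group away entirely: hydrogen in place of isobutoxycarbonyl on an oxygen on a saturated carbon. Among the compounds with values here, no measured step covers removal of the whole acyl group; the only known step exchanges one such group for another, so it bears on this change loosely at best. With little to anchor it, the estimate for compound 3 is 25%, expected to fall between 5% and 55%. The expected step is a number 11.8 percentage points higher from compound 2 to compound 3 (beyond the scatter).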

Compound 3, a percentage reported as inhibition, in the whole organism at one dose (the size of the read-out at that dose, not a potency): 45.7%
For compound 3 the middle estimate is 20.7 percentage points below the measured one, within the range that was stated.
By their numbers in this assay, from the lowest: compound 2; then compound 1; then compound 3.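

In this assay, removing the acyl group from this oxygen raises the read-out from either ester-type form: the change is a number 32.5 percentage points higher from compound 2 to compound 3 (beyond the scatter) for the isobutoxycarbonyl group and a number 17.2 percentage points higher from compound 1 to compound 3 (beyond the scatter) for the propylcarbonyl group. Within the data shown here, the earlier pair showed only that one acyl group differed from another, whereas these steps show that neither group is needed for inhibition at this dose and that the plain hydroxy form gives the highest number of the three. No supporting measurement is available to explain these differences.

From the compounds shown here alone, it remains open whether a shorter acyl group such as acetyl, or an ester carrying an amine such as that of glycine, would track the free hydroxy or the two larger groups. A methyl ether on this oxygen, which would lack the carbonyl, is also unaddressed by these compounds.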